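The source may hold more compounds than are shown below. What is called first, only, known or untested is meant among the compounds shown, and "the series" means these compounds.

Compounds measured in a functional assay on PBMC cells (Homo sapiens) for inhibition, read by HTRF, with stated times of 15 min and 24 h; on this read-out lower numbers stand for stronger inhibition and higher numbers for weaker inhibition:
compound 1 `O=C(Nc1ccc2c(c1)B(O)OC2)c1c(F)cccc1C(F)(F)F`: 370 nM
compound 2 `O=C(Nc1ccc2c(c1)B(O)OC2)c1cccc(C(F)(F)F)c1F`: > 100000 nM
compound 3 `O=C(Nc1ccc2c(c1)B(O)OC2)c1cccc(Cl)c1F`: > 100000 nM

Among the measured compounds shown here, compound 1 gives the only number in this assay. For compound 2 the value is a limit of this assay. For compound 3 the value is likewise a limit. The difference between the core of compound 1 and the core of compound 2 is not broken down here. From compound 2 to compound 3 the change is chloro in place of trifluoromethyl on an aromatic carbon and gives a step that the two limits leave unreadable from compound 2 to compound 3, because the limit of > 100000 nM in this assay, at which 2 of the 3 values shown sit, holds both ends of that step.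

Compound 4 `O=C(Nc1ccc2c(c1)B(O)OC2)c1c(F)cccc1Cl` is not yet measured. From compound 1 to compound 4 the change is chloro in place of trifluoromethyl on an aromatic carbon. It is the same kind of change as from compound 2 to compound 3, but not the same: in compound 4 the changed carbon is ortho to a large group and meta to a fluoro group, whereas in compound 3 it is ortho to a fluoro group and meta to a large group. The measured step gives no readable size, so the expectation for compound 4 rests mainly on the value of compound 1 370 nM and is held wide. Compound 4 is expected to show a 3.2-fold higher number from compound 1 to compound 4 (0.51 log units; beyond the scatter) in this assay. Compound 4 is estimated at 1200 nM, between 300 nM and 8000 nM.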

Compound 4, half-maximal inhibitory concentration: 4900 nM
For compound 4 the middle estimate is 4.1-fold (0.61 log units) below the measured one; the measured number falls inside the stated range.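

On the core of compound 1, chloro in place of trifluoromethyl gives a 13-fold higher number from compound 1 to compound 4 (1.12 log units; beyond the scatter) in this assay, so on this core the change clearly weakens inhibition. The same change from compound 2 to compound 3 cannot be read, because both of its ends rest on one limit of the assay: the limit of > 100000 nM in this assay, at which 2 of the 4 values shown sit. The size seen here therefore holds for the core of compound 1 alone, and whether the change carries over to the core of compound 2, in size or even in direction, is not shown.

Chloro and trifluoromethyl are the only two groups compared at this carbon, so the compounds shown leave open how a methyl, a methoxy group, a nitrile or an amine would behave in the same place on the core of compound 1. They also leave open whether any of these groups would bring the core of compound 2 off the limit.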